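The compounds below may be only part of what the source reports. "The series", "measured", "known", "first", "only" and "open" are said of these compounds alone.

Compound 1 `Nc1ncnc2c1ncn2[C@@H]1O[C@H](COC(=O)NCc2ccccc2)[C@@H](O)[C@H]1O`, compound 2 `Nc1ncnc2c1nc(NCc1cccc3ccccc13)n2[C@@H]1O[C@H](CO)[C@@H](O)[C@H]1O` and compound 3 `Nc1ncnc2c1nc(NCc1ccc(Cl)cc1)n2[C@@H]1O[C@H](CO)[C@@H](O)[C@H]1O` were measured in an assay on COS-7 cells for inhibition of sodium/nucleoside cotransporter 2 (Homo sapiens), read by scintillation counting, in the presence of a further agent that is not named here; a higher number here means a weaker inhibitor, a lower number a stronger inhibitor. Compound 1 reaches only the limit of this assay, giving > 100000 nM. Compound 2 gives 5700 nM. Compound 3 gives 11000 nM.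

So compound 1 holds no number of its own, only a limit, while compounds 2 and 3 do. Compound 4 `CNC(=O)OC[C@H]1O[C@@H](n2cnc3c(N)ncnc32)[C@H](O)[C@@H]1O` differs from compound 1 by hydrogen in place of phenyl on a saturated chain carbon bound to an amide-type nitrogen. Going by the values given here, the single measured step, a 1.9-fold higher number from compound 2 to compound 3 (0.29 log units; within the scatter), alters a different place and lies within the scatter, so no measured step covers the saturated chain carbon bound to an amide-type nitrogen. Compound 4 is therefore expected to stay near compound 1, most likely again at the limit, as the expected step that the limit leaves unreadable from compound 1 to compound 4 shows. The estimate for compound 4 is 150000 nM, ranging from 50000 nM to 500000 nM.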

Compound 4, half-maximal inhibitory concentration: > 100000 nM
Compound 4 was reported as a limit; the forecaster's own chance of this, stated with the estimate: 80%; the middle value is on the limit's open side.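

Compound 1 and compound 4 each give only a limit, not a number, so no step can be read between them: the limit of > 100000 nM in this assay, at which 2 of the 4 values shown sit. Going by these compounds, whether hydrogen in place of phenyl changes the strength of inhibition at all stays open.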